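A few compounds are considered here, and "the series" means these few. Any claim that something is new, unique, unknown or untested is made for them only; others in the source may bear on it.

Series notes, cytotoxicity. Compound 2 `CC(C)Cc1nn(-c2nccs2)cc1C(=O)NCc1cccc(F)c1` is the reference point. In a toxicity assay on HepG2 2.2.15 cells (Homo sapiens) for cytotoxicity, read by CCK-8 assay, with a stated time of 8 days (on this read-out lower numbers stand for higher toxicity in this test and higher numbers for lower toxicity in this test), compound 2 gives > 100000 nM, which is a limit of the assay and not a number. Compound 1 `CCOC(=O)c1cn(-c2nccs2)nc1CC(C)C` shares the core. In this assay compound 1 gives > 100000 nM, again a limit. Compound 3 `CCOC(=O)c1cn(-c2ccc(C(=O)O)cc2)nc1CC(C)C` shares the core as well. In this assay compound 3 gives > 100000 nM, also a limit. Compound 2 therefore stands where every value shown stands, namely at the limit of > 100000 nM in this assay, at which 3 of the 3 values shown sit. Within the data shown here, no compound has a measured number, so no step between measured compounds can be stated, and no structural change within the measured set has any known effect on this read-out.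

Compound 4 `CC(C)Cc1nn(-c2nccs2)cc1C(=O)NCc1ccccc1F` has not yet been measured. It differs from compound 2 by 2-fluorophenyl in place of 3-fluorophenyl on a saturated chain carbon bound to an amide-type nitrogen. With three of three values sitting at the limit, the expected step from compound 2 to compound 4 in this assay is none beyond the scatter, a number no higher from compound 2 to compound 4 (the limit leaves the size open). The most likely outcome for compound 4 in this assay is expected to be another limit rather than a number. Compound 4 is estimated at 100000 nM, with an expected range from 50000 nM to 200000 nM.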

Compound 4, half-maximal cytotoxic concentration: > 100000 nM
Compound 4 was reported as a limit; the forecaster's own chance of this, stated with the estimate: 85%; the middle value lies on the limit itself.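

In this assay compound 4 gives > 100000 nM, a limit and not a number. Compound 2 also sits at a limit, so no step can be read between compound 2 and compound 4. The compounds shown leave open at what concentration any of them would become cytotoxic, and whether 2-fluorophenyl and 3-fluorophenyl differ at all on this read-out.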